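Cyclopropyloxy to isopropoxy on a shared core

The source may report more compounds than this note shows. Statements on the series, on what has been measured and on what is new or still open speak of the compounds shown alone.

Measured in a functional assay on MV4-11 cells (Homo sapiens) for antiproliferative activity, read by CCK-8 assay, with a stated time of 72 h; a higher number here means a weaker inhibitor, a lower number a stronger inhibitor:
- Compound 1 `Cc1cc(F)cc(C)c1Oc1ccc(C(C)(C)O)cc1-c1cn(C)c(=O)c2[nH]c(C(=O)NCc3ccc(C(=O)NO)cc3)cc12`: 440 nM
- Compound 2 `Cn1cc(-c2cc(C(C)(C)O)ccc2OC2CC2)c2cc(C(=O)NCc3ccc(C(=O)NO)cc3)[nH]c2c1=O`: 420 nM

In this assay, going by the values given here, compound 2 gives 420 nM, and compound 1, the only other measured compound, lies within the scatter of it. Compound 3 `CC(C)Oc1ccc(C(C)(C)O)cc1-c1cn(C)c(=O)c2[nH]c(C(=O)NCc3ccc(C(=O)NO)cc3)cc12` keeps the shared core and differs from compound 2 in one group: isopropyl in place of cyclopropyl on an oxygen on an aromatic ring. Thus isopropyl stands in place of cyclopropyl on an oxygen on an aromatic ring.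

Among the compounds with values here, one measured step bears on this place: a 1.0-fold lower number from compound 1 to compound 2 (0.02 log units; within the scatter), where cyclopropyl replaces 4-fluoro-2,6-dimethylphenyl on the same oxygen. That step stays within the scatter. Within the data shown here, no measured compound yet carries isopropyl there, so the evidence is indirect. Even so, the flat step to compound 2 gives no reason to expect a change beyond the scatter in this assay, and no direction is favoured.

The estimated step is no change at the digits printed from compound 2 to compound 3 (within the scatter). For compound 3 the expected value is 420 nM, with an estimated range of 200 nM to 850 nM.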

Compound 3, half-maximal inhibitory concentration: 350 nM
The estimate for compound 3 lay 1.2-fold (0.08 log units) above the measured number, and the stated range covers the measured number.
By their numbers in this assay, from the lowest: compounds 3, 2 and 1 (each within the scatter of the next).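

Replacing the cyclopropyl group with isopropyl removes the three-membered ring from the group on the oxygen, and in this assay this change gives a 1.2-fold lower number from compound 2 to compound 3 (0.08 log units; within the scatter) and leaves the reading in the same range. The ring of the cyclopropyl group is therefore not needed to keep the antiproliferative activity seen with compound 2, a point the earlier pair could not address because both of its groups contain a ring. The larger swap gives a 1.3-fold lower number from compound 1 to compound 3 (0.10 log units; within the scatter) in the same assay, so an open-chain group, a small ring and 4-fluoro-2,6-dimethylphenyl on this oxygen all give values within the scatter of one another. Going by these compounds alone, nothing available explains why these groups read alike and the three compounds offer only this flat comparison.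

As far as these compounds go, it remains open whether this position stays as flat with a group of another kind on the oxygen, such as an amine, a carboxylic acid or a longer chain. These compounds also leave open whether the same flatness would hold in any setting other than these cells.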